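Amino-bearing ring replacing 4-methylphenyl: expected loss of inhibition

A few compounds are considered here, and "the series" means these few. Any claim that something is new, unique, unknown or untested is made for them only; others in the source may bear on it.

Measured in a functional assay on RBL-2H3 cells (Rattus norvegicus) for inhibition, with stated times of 30 min and 1 h; on this read-out higher numbers stand for weaker inhibition and lower numbers for stronger inhibition:
- compound 1 `COc1ccc(CN(CCN(C)C)c2ccc(Cl)cc2)cc1`: 40.2 nM
- compound 2 `COc1ccc(CN(CCN(C)C)c2ccc(N)cc2)cc1`: 4060 nM
- compound 3 `COc1ccc(CN(CCN(C)C)c2ccc(C)cc2)cc1`: 89.1 nM

Compound 3 stands in the middle of the three numbers: a 2.2-fold higher number from compound 1 to compound 3 (0.35 log units; beyond the scatter) is modest, whereas a 46-fold lower number from compound 2 to compound 3 (1.66 log units; beyond the scatter) is large. The next entry, compound 4 `COc1ccc(CN(CCN(C)C)c2ccc(N)cn2)cc1`, has not yet been measured in this assay. Its structural change from compound 3 is 5-aminopyridin-2-yl in place of 4-methylphenyl on an amine nitrogen. The entering group carries an amino group, as compound 2 does, so the amino steps are the closest guide: a 100-fold higher number from compound 1 to compound 2 (2.00 log units; beyond the scatter) and the large step from compound 2 already given. Among the compounds with values here, no measured step isolates the hetero atom in the entering ring, so the range is kept wide. A large rise in the number is expected, to about the level of compound 2 at 4060 nM. The expected change is an estimated 45-fold higher number from compound 3 to compound 4 (1.65 log units; beyond the scatter). For compound 4 the estimated value is 4000 nM, with an expected range of 800 nM to 20000 nM.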

Compound 4, half-maximal inhibitory concentration: 2110 nM
Compound 4: the middle estimate sits 1.9-fold (0.28 log units) above what was measured, within the range that was stated.
By their numbers in this assay, from the lowest: compound 1; then compound 3; then compounds 4 and 2 (each within the scatter of the next).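

In this assay, the 5-aminopyridin-2-yl group on the amine nitrogen gives a 24-fold higher number from compound 3 to compound 4 (1.37 log units; beyond the scatter) and a 52-fold higher number from compound 1 to compound 4 (1.72 log units; beyond the scatter), so the large rise seen earlier with 4-aminophenyl is not confined to a ring of carbon only. Against the 4-aminophenyl group of compound 2, it gives a 1.9-fold lower number from compound 2 to compound 4 (0.28 log units; within the scatter), so the hetero atom in the ring brings no change that can be told from the scatter while the amino group is present. Compounds 2 and 4, the two amino-bearing members, therefore sit together, well above compounds 1 and 3, and nothing at hand accounts for this.

Whether the hetero atom matters without the amino group stays open, as 5-chloropyridin-2-yl and 5-methylpyridin-2-yl lie outside the compounds shown. Also open, on these data alone, is how a hydroxyl or an acetamide would compare with the amino group on these rings.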